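Halogen swap at the benzyl group of compound 2

The compounds below may be only part of what the source reports. "The series", "measured", "known", "first", "only" and "open" are said of these compounds alone.

Measured compounds:
compound 1 `O=C(/C=C/c1ccc(OCc2cn(Cc3ccccc3Br)nn2)cc1)c1ccc([N+](=O)[O-])cc1`: 42%
compound 2 `O=C(/C=C/c1ccc(OCc2cn(Cc3ccc(Br)cc3)nn2)cc1)c1ccc([N+](=O)[O-])cc1`: 18%

In a functional assay on A549 cells (Homo sapiens) for inhibition, read by MTT assay, with a stated time of 48 h, tested at 10 uM (a lower number here means less inhibition of growth, a higher number more inhibition of growth at the concentration tested), compound 2 stands lowest of the two numbers; its nearest neighbour is compound 1, which sits higher by a step that is beyond the scatter, a number 24 percentage points lower from compound 1 to compound 2 (beyond the scatter). Among the measured compounds shown here, that step moved the bromo from one ring carbon to another and is the only step measured.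

Compound 3 `O=C(/C=C/c1ccc(OCc2cn(Cc3ccc(F)cc3)nn2)cc1)c1ccc([N+](=O)[O-])cc1` differs from compound 2 by fluoro in place of bromo on an aromatic carbon, the same difference read one bond further out being 4-bromobenzyl to 4-fluorobenzyl.

For the measured compounds named here, no measured step changes the halogen itself; the step from compound 1 to compound 2 concerns the position of the bromo, not its identity, so it does not bear directly on this change. With nothing in the series to indicate a shift in either direction, the expected step in this assay is none beyond the scatter, no change at the digits printed from compound 2 to compound 3 (within the scatter). Compound 3 is therefore estimated at 18%, with a range from 5% to 35%.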

Compound 3, percent growth inhibition at one concentration: 34%
For compound 3 the middle estimate is 16 percentage points below the measured one; the range from low to high includes it.
By their numbers in this assay, from the lowest: compound 2; then compounds 3 and 1 (each within the scatter of the next).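

In this assay, the identity of the halogen on this aromatic carbon matters as well as its position: fluoro in place of bromo gives a number 16 percentage points higher from compound 2 to compound 3 (beyond the scatter). The low number of compound 2 therefore cannot be read as a general result for a halogen at this place, since 4-fluorophenyl in place of 2-bromophenyl gives a number 8 percentage points lower from compound 1 to compound 3 (within the scatter), a change that stays within what repeat measurements would produce. Nothing available explains why bromo and fluoro part here, so the step stands as an observation only.

With only bromo and fluoro at this place, the compounds shown cannot say whether the number tracks the halogen in any ordered way or whether 4-bromophenyl is simply a single low point, and a chloro group, a methoxy group or an amine on the same aromatic carbon would help separate these readings. As far as these compounds go, the 2-fluorophenyl counterpart also remains open, so it is unknown whether the effect of moving the halogen seen with bromo would persist with fluoro.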